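The source may hold more compounds than are shown below. What is called first, only, known or untested is meant among the compounds shown, and "the series" means these compounds.

Compounds measured in a functional assay on HT-29 cells (Homo sapiens) for antiproliferative activity, read by MTT assay, with a stated time of 48 h; a higher number here means a weaker inhibitor, a lower number a stronger inhibitor:
compound 1 `O=C(/C=C\Nc1ccc(F)cc1)c1cn(-c2ccccc2)nc1-c1ccc(F)cc1`: 6500 nM
compound 2 `O=C(/C=C\Nc1ccc(Cl)cc1)c1cn(-c2ccccc2)nc1-c1ccc(F)cc1`: 4600 nM

Compound 2 stands within the scatter of compound 1: the step of a 1.4-fold lower number from compound 1 to compound 2 (0.15 log units; within the scatter) is too small to count as a real difference, so on the numbers shown the two compounds are effectively alike.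

Compound 3 `O=C(/C=C\Nc1ccc(C(F)(F)F)cc1)c1cn(-c2ccccc2)nc1-c1ccc(F)cc1` is the next step along the same edge of the molecule. It differs from compound 2 by trifluoromethyl in place of chloro on an aromatic carbon. Among the measured compounds shown here, only one measured step bears on this change, the move from fluoro to chloro at that position, and that step a 1.4-fold lower number from compound 1 to compound 2 (0.15 log units; within the scatter) was within the scatter. With nothing beyond that to go on, no step beyond the scatter is expected in this assay for compound 3, and the estimate simply sits near compound 2.

The expected step is a 1.2-fold lower number from compound 2 to compound 3 (0.06 log units; within the scatter). Compound 3 is therefore estimated at 4000 nM, with a range from 1500 nM to 11000 nM.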

Compound 3, half-maximal inhibitory concentration: > 50000 nM
Compound 3 gave a limit, no number; the forecaster's own chance of this, stated with the estimate: 5%; middle value at least 12-fold (1.09 log units) from the limit.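

Compound 3 gives no number in this assay, only a limit: the limit of > 50000 nM in this assay, at which 1 of the 3 values shown sits. The position para to a large group is therefore not indifferent to what it carries: fluoro and chloro there stand within the scatter of each other, yet trifluoromethyl brings an at least 10-fold higher number from compound 2 to compound 3 (1.03 log units; beyond the scatter) and an at least 7.6-fold higher number from compound 1 to compound 3 (0.88 log units; beyond the scatter). A single group exchange at this place can thus separate compounds that are otherwise the same, and the step from fluoro to chloro gave no sign of this.

From the compounds shown here alone, it remains open whether this drop is particular to trifluoromethyl or would also appear with other groups at this position, such as a methyl, a methoxy, an amine or a carboxylic acid. The three compounds shown also leave open whether the same exchange would have a similar effect elsewhere on the shared core.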